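The source may report more compounds than this note shows. Statements on the series, on what has been measured and on what is new or still open speak of the compounds shown alone.

Working notes on the series. Among the measured compounds shown here, in a functional assay (a lower number here means a stronger inhibitor, a higher number a weaker inhibitor), compound 1 `CC(C)=CCOc1cc(O)c2c(c1)OC(c1ccccc1)CC2=O` gives 7320 nM and compound 2 `CC(C)=CCOc1cc(O)c2c(c1)OC(c1ccc(Cl)cc1Cl)CC2=O` gives 3340 nM, the lower of the two numbers so far. Next comes compound 3 `CC(C)=CCOc1cc(O)c2c(c1)OC(c1ccc(Br)cc1)CC2=O`, with 4-bromophenyl in place of 2,4-dichlorophenyl on a saturated ring carbon, next to the ring oxygen (4-bromophenyl in place of 2,4-dichlorophenyl on a saturated ring carbon). For the measured compounds named here, only one measured step bears on this change: a 2.2-fold lower number from compound 1 to compound 2 (0.34 log units; beyond the scatter), a modest step beyond the scatter, from phenyl to 2,4-dichlorophenyl at the same carbon. Going by the values given here, no measured compound carries 4-bromophenyl, so that single step is a weak guide. In this assay, a step no larger than that one is expected, towards a somewhat higher number and possibly within the scatter, estimated as a 1.3-fold higher number from compound 2 to compound 3 (0.10 log units; within the scatter). The expected value for compound 3 is 4200 nM, with an estimated range of 1800 nM to 9500 nM.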

Compound 3, half-maximal inhibitory concentration: 2770 nM
Beside the measured number, compound 3's estimate is 1.5-fold (0.18 log units) above it; low and high end bracket the measured number.
By their numbers in this assay, from the lowest: compounds 3 and 2 (each within the scatter of the next); then compound 1.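

In this assay, 4-bromophenyl at this saturated ring carbon cannot be told apart from 2,4-dichlorophenyl: a 1.2-fold lower number from compound 2 to compound 3 (0.08 log units; within the scatter) is the step, so the change of halogen pattern on this ring has no readable effect here. Set against the unsubstituted phenyl, bromo in place of hydrogen on an aromatic carbon gives a 2.6-fold lower number from compound 1 to compound 3 (0.42 log units; beyond the scatter) as a modest step, the second one out of phenyl at this carbon. Among the compounds shown here, both halogen-bearing rings therefore stand apart from phenyl by similar modest steps, with no compound among the three going against this.

As far as these compounds go, whether a methoxy group or an amine in place of the bromo would hold the lower number remains open. Nothing measured on these compounds accounts for the steps.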